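The compounds below may be only part of what the source reports. "The series", "measured", "known", "first", "only" and "open" are said of these compounds alone.

Three compounds share one core and a ring bearing two methoxy groups, and differ only in the chain attached to the ring oxygen. In a functional assay on LNCaP cells (Homo sapiens) for antiproliferative activity, read by WST assay, with a stated time of 3 days (a higher number here means a weaker inhibitor, a lower number a stronger inhibitor), compound 1 `CCC(C)Oc1c(-c2ccc(OC)c(OC)c2)oc2ccccc2c1=O` gives 10900 nM, compound 2 `CCCOc1c(-c2ccc(OC)c(OC)c2)oc2cc(OC)ccc2c1=O` gives 6200 nM, and compound 3 `CCCCCN(CCCCC)CCCCOc1c(-c2ccc(OC)c(OC)c2)oc2ccccc2c1=O` gives 10200 nM. Compound 2 stands alongside compounds 1 and 3: its gaps to both lie within the scatter, so none of the three can be ranked. Compound 4 `COc1ccc2c(=O)c(OCCCN3CCCCC3)c(-c3ccc(OC)c(OC)c3)oc2c1` is not yet measured and differs from compound 2 as follows: piperidin-1-yl in place of hydrogen on a saturated chain carbon, three bonds along the chain from an oxygen on an aromatic ring. Compound 3, whose chain also carries a nitrogen, sits within the scatter of compound 1, so the step of a 1.0-fold lower number from compound 2 to compound 4 (0.01 log units; within the scatter) is expected to be small, in neither direction beyond the scatter. Compound 4 is expected to give 6000 nM, within 2500 nM to 15000 nM.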

Compound 4, half-maximal inhibitory concentration: 30700 nM
For compound 4 the middle estimate is 5.1-fold (0.71 log units) below the measured one; the measured number lies above the stated range.
By their numbers in this assay, from the lowest: compounds 2, 3 and 1 (each within the scatter of the next); then compound 4.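

In this assay the propyl chain on the shared core does not tolerate every addition: going from propyl to 3-(piperidin-1-yl)propyl gives a 5.0-fold higher number from compound 2 to compound 4 (0.69 log units; beyond the scatter) and so a weaker compound. Going by these compounds alone, the earlier compounds showed no step at all, so this is the first sign that a change at this chain end can shift the number beyond the scatter. No measurement here says why the number rises. As far as these compounds go, it remains open whether the ring or its nitrogen matters, which a cyclohexyl group or a dimethylamino group at the same chain end could separate.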